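This account rests on a few compounds, and the source may have more. Where it says the series, first, only, none or still open, it means among the compounds named here.

- compound 1 `C=C(CCCC)C(=O)c1ccc(OC(C)C(=O)OC)c(C)c1C`: 5200 nM
- compound 2 `C=C(CCC)C(=O)c1ccc(OC(C)C(=O)OC)c(C)c1C`: 5600 nM

In a functional assay on HL-60 cells (Homo sapiens) for antiproliferative activity, with a stated time of 72 h (on this read-out lower numbers stand for stronger inhibition of growth and higher numbers for weaker inhibition of growth), compound 2 at 5600 nM lies within the scatter of compound 1. Compound 3 `C=C(C)C(=O)c1ccc(OC(C)C(=O)OC)c(C)c1C` differs from compound 2 as follows: hydrogen in place of ethyl on a saturated chain carbon bound to a double-bonded chain carbon. In words, this is hydrogen in place of ethyl on a saturated chain carbon bound to a double-bonded chain carbon. Within the data shown here, the only measured step bearing on it is the trimming of the same chain, a 1.1-fold higher number from compound 1 to compound 2 (0.03 log units; within the scatter), which stayed within the scatter. The present change is larger, so only a small loss of growth inhibition, if any, is expected. The expected step is a 1.2-fold higher number from compound 2 to compound 3 (0.06 log units; within the scatter), probably not beyond the scatter. For compound 3 the estimated value is 6500 nM, with an expected range of 2800 nM to 15000 nM.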

Compound 3, concentration for 50% growth inhibition: 6000 nM
The estimate for compound 3 lay 1.1-fold (0.03 log units) above the measured number; the range from low to high includes it.
By their numbers in this assay, from the lowest: compounds 1, 2 and 3 (each within the scatter of the next).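

In this assay, hydrogen in place of ethyl gives a 1.1-fold higher number from compound 2 to compound 3 (0.03 log units; within the scatter) and hydrogen in place of propyl gives a 1.2-fold higher number from compound 1 to compound 3 (0.06 log units; within the scatter), so even the largest cut shown stays within the scatter. On this saturated chain carbon bound to a double-bonded chain carbon, compounds 1, 2 and 3 cannot be told apart, whatever the chain length among them. Nothing at hand accounts for this flat result.

Open, as far as these compounds go, is whether a much longer chain, a phenyl group or a terminal amine at this place would leave the number unmoved. The compounds shown also say nothing about changes elsewhere on the shared core.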